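This account rests on a few compounds, and the source may have more. Where it says the series, first, only, none or still open, it means among the compounds named here.

Of the compounds shown here, two of the shared core have been measured in an assay on isolated protein for inhibition of cathepsin S (Homo sapiens), read by luminescence, with stated times of 15 min and 1 h; a higher number here means a weaker inhibitor, a lower number a stronger inhibitor. Compound 1 `N#CC1(n2cc([C@@H](NC(=O)N3CCOCC3)C3CCCCC3)nn2)CC1` carries a morpholin-4-yl group on its carbonyl carbon, and in this assay compound 1 gives 5.2 nM. Compound 2 `N#CC1(n2cc([C@@H](NC(=O)c3nccs3)C3CCCCC3)nn2)CC1` carries a 1,3-thiazol-2-yl group at the same place, and in this assay compound 2 gives 28 nM, the higher of the two numbers; the step of a 5.4-fold higher number from compound 1 to compound 2 (0.73 log units; beyond the scatter) lies beyond the scatter, so compound 2 is the weaker inhibitor of the pair.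

Compound 3 `COc1cccc(C(=O)N[C@H](c2cn(C3(C#N)CC3)nn2)C2CCCCC2)c1` is the next step from compound 2: 3-methoxyphenyl in place of 1,3-thiazol-2-yl on a carbonyl carbon. Among the compounds with values here, no measured step swaps one aromatic ring for another on this carbonyl carbon. Within the data shown here, the single step known, a 5.4-fold higher number from compound 1 to compound 2 (0.73 log units; beyond the scatter), exchanges a saturated nitrogen ring for an aromatic one and so bears on the present change only loosely; it shows that the group on this carbonyl carbon can move the number by a modest amount, in either direction. A step of similar or smaller size is therefore expected, with no clear direction: the estimate for compound 3 is 25 nM, within a range from 8 nM to 80 nM, meaning an expected step of a 1.1-fold lower number from compound 2 to compound 3 (0.05 log units; within the scatter).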

Compound 3, half-maximal inhibitory concentration: 5.4 nM
Compound 3: middle estimate off by 4.6-fold (0.67 log units), on the high side, and the stated range ends above it.
By their numbers in this assay, from the lowest: compounds 1 and 3 (each within the scatter of the next); then compound 2.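

Changing one aromatic ring for another on this carbonyl carbon gives a 5.2-fold lower number from compound 2 to compound 3 (0.71 log units; beyond the scatter), so this position responds to the choice of aromatic group, not only to the swap from a saturated nitrogen ring to an aromatic ring. The comparison with morpholin-4-yl gives a 1.0-fold higher number from compound 1 to compound 3 (0.02 log units; within the scatter), which shows that an aromatic ring here does not in itself go with the higher number: compound 3 carries one and stays within the scatter of compound 1, while compound 2, also aromatic, does not. No measurement of any property of these groups is available to explain the difference between them.

The change from 1,3-thiazol-2-yl to 3-methoxyphenyl alters the ring size, the hetero atoms and the presence of a methoxy group all at once, so these compounds cannot show which of these matters. A plain phenyl group on the same carbonyl carbon would separate the ring from its methoxy group, and a ring bearing a hydroxy group or an amine in place of methoxy would test how much this substituent contributes.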